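A few compounds are considered here, and "the series" means these few. Any claim that something is new, unique, unknown or untested is made for them only; others in the source may bear on it.

Measured compounds:
Compound 1, `Cc1cc(C)cc(C(=O)N(CC(=O)NCc2ccccc2)Cc2ccc(C(=O)Nc3cc(F)ccc3N)cc2)c1` — in an assay on Sf9 cells for inhibition of protein deacetylase HDAC6 (Homo sapiens), read by fluorescence, with a stated time of 90 min (on this read-out higher numbers stand for weaker inhibition and lower numbers for stronger inhibition), compound 1 gives > 10000 nM, which is a limit of the assay and not a number.
Compound 2, `Nc1ccccc1NC(=O)CCCCCN(CC(=O)NCc1ccccc1)C(=O)c1cccc2ccccc12` — in this assay compound 2 gives > 10000 nM, again a limit rather than a number.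
Compound 3, `Cc1ccc(CNC(=O)CN(CCCCCC(=O)Nc2ccccc2N)C(=O)c2cc(C)cc(C)c2)cc1` — in this assay compound 3 gives > 10000 nM, also a limit rather than a number.

Where compound 3 stands is therefore simple: it sits at the limit of this assay, and so do the other two measured compounds, so no ordering among them can be drawn; this is shown by the limit of > 10000 nM in this assay, at which 3 of the 3 values shown sit.

Compound 4, `COc1ccc(CNC(=O)CN(CCCCCC(=O)Nc2ccccc2N)C(=O)c2cc(C)cc(C)c2)cc1`, is not yet measured. It differs from compound 3 in one place: methoxy in place of methyl on an aromatic carbon. The pair is methyl against methoxy on the aromatic carbon of a six-membered carbon ring, para to a large group, so that 4-methylbenzyl becomes 4-methoxybenzyl.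

Among the measured compounds shown here, since compound 3 returns only a limit in this assay, and every measured compound does the same, there is no measured step to build on. The expectation is that compound 4 moves no further than the scatter from compound 3, the expected step from compound 3 to compound 4 being a step that the limit leaves unreadable from compound 3 to compound 4. Compound 4 is thus estimated at 20000 nM in this assay, within 8000 nM to 60000 nM, most likely reported again as a limit rather than a number.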

Compound 4, half-maximal inhibitory concentration: > 10000 nM
Compound 4 ended at the assay's limit (the forecaster's own chance of this, stated with the estimate: 85%); the middle value is on the limit's open side.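

In this assay compound 4 gives > 10000 nM, which is a limit and not a number. No step from compound 3 to compound 4 can be read, as both compounds sit at the same limit: the limit of > 10000 nM in this assay, at which 4 of the 4 values shown sit.

The compounds shown leave open what effect, if any, the change from 4-methylbenzyl to 4-methoxybenzyl has on inhibition in this assay.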